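This account rests on a few compounds, and the source may have more. Where it says the series, first, only, none or still open, it means among the compounds named here.

Compound 1, `O=C(NCc1ccc(CNS(=O)(=O)c2ccccc2)cc1)c1ccccc1F`, was tested in an assay on MDA-MB-231 cells for binding affinity to C-X-C chemokine receptor type 4 (Homo sapiens), read by immunofluorescence and microscopy, with stated times of 10 min and 30 min (on this read-out higher numbers stand for an effect only at larger amounts of compound and lower numbers for an effect already at smaller amounts), and compound 1 gave 1000 nM. Compound 2, `Cc1ccc(S(=O)(=O)NCc2ccc(CNC(=O)c3ccccc3F)cc2)cc1`, differs from compound 1 by methyl in place of hydrogen on an aromatic carbon. In this assay compound 2 gives 1000 nM, and the step is no change at the digits printed from compound 1 to compound 2 (within the scatter). Compound 3, `O=C(NCc1ccc(CNS(=O)(=O)c2ccccc2)cc1)c1c(Cl)cc(Cl)cc1Cl`, differs from compound 1 at the other end of the shared core by 2,4,6-trichlorophenyl in place of 2-fluorophenyl on a carbonyl carbon. In this assay compound 3 gives 10 nM, and the step is a 100-fold lower number from compound 1 to compound 3 (2.00 log units; beyond the scatter). Compound 3 therefore has the lowest number of the three measured compounds, with both compound 1 and compound 2 beyond the scatter away from it.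

Compound 4, `Cc1ccc(S(=O)(=O)NCc2ccc(CNC(=O)c3c(Cl)cc(Cl)cc3Cl)cc2)cc1`, has not yet been measured in this assay. It differs from compound 3 by methyl in place of hydrogen on an aromatic carbon. This is the same change that separates compound 1 from compound 2, here made on the core of compound 3 rather than on the core of compound 1; the two cores differ in the way already described for compound 1 and compound 3, and the surroundings of the changed position read the same in both cases. Because no change at the digits printed from compound 1 to compound 2 (within the scatter) showed no change within the scatter, compound 4 is expected to stand close to compound 3, with an expected step of no change at the digits printed from compound 3 to compound 4 (within the scatter). Compound 4 is therefore estimated at 10 nM, with an expected range from 4 nM to 25 nM. This expectation rests on a single measured pair and is correspondingly tentative.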

Compound 4, effective concentration (reported as EC, without a stated level of effect): 10 nM
For compound 4 middle estimate and measured number coincide at the digits printed, and the stated range covers the measured number.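

In this assay, methyl in place of hydrogen on an aromatic carbon gives no change at the digits printed from compound 3 to compound 4 (within the scatter), which matches the result of the same change on the core of compound 1: the same change on two cores in this assay, no change at the digits printed (within the scatter) from compound 1 to compound 2 and no change at the digits printed (within the scatter) from compound 3 to compound 4, 1.0-fold (0.00 log units) apart, within the scatter of two such steps The change from 2-fluorophenyl to 2,4,6-trichlorophenyl on a carbonyl carbon, now read on the methyl-bearing core, gives a 100-fold lower number from compound 2 to compound 4 (2.00 log units; beyond the scatter), and this large step also carries over from one core to the other: the same change on two cores in this assay, a 100-fold lower number (2.00 log units; beyond the scatter) from compound 1 to compound 3 and a 100-fold lower number (2.00 log units; beyond the scatter) from compound 2 to compound 4, 1.0-fold (0.00 log units) apart, within the scatter of two such steps Across these four compounds each change therefore has the same outcome on both cores, with no compound going against this, but each comparison rests on just two cores and shows neither that the agreement extends to other cores or other groups nor why either change has the outcome it does.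

The compounds shown leave open whether a group other than methyl at that place, such as a methoxy group, an amine or a carboxylic acid, would also leave the number in the same range. They also leave open whether all three chlorine atoms are needed for the large step, or whether a phenyl group carrying only one or two chlorine atoms would give the same result.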